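The source may report more compounds than this note shows. Statements on the series, on what has been measured and on what is new or still open speak of the compounds shown alone.

Three compounds share one core and differ only in the tail on the amide. In an in vitro assay on BaF3 cells for displacement of a labelled ligand from C-X-C chemokine receptor type 3 (Homo sapiens) (a higher number here means a weaker inhibitor, a lower number a stronger inhibitor), compound 1 `CC[C@H]1CN(c2nc(N)c(C(N)=O)nc2Cl)CCN1C1CCN(C(=O)c2ccc(Cl)cc2)CC1` gives 76 nM, compound 2 `CC[C@H]1CN(c2nc(N)c(C(=O)NC)nc2Cl)CCN1C1CCN(Cc2ccc(Cl)cc2)CC1` gives 0.3 nM, and compound 3 `CC[C@H]1CN(c2nc(N)c(C(=O)NCCNS(=O)(=O)C(F)(F)F)nc2Cl)CCN1C1CCN(Cc2ccc(Cl)cc2)CC1` gives 0.9 nM. Compound 3 therefore stands second highest of the three numbers in this assay: its nearest neighbour is compound 2, while compound 1 lies far above both. The step of a 3.0-fold higher number from compound 2 to compound 3 (0.48 log units; beyond the scatter) shows that attaching a (((trifluoromethyl)sulfonyl)amino)methyl group to the chain carbon bound to the amide nitrogen raised the number by a modest amount. Compound 4 `CC[C@H]1CN(c2nc(N)c(C(=O)NCCS(C)(=O)=O)nc2Cl)CCN1C1CCN(Cc2ccc(Cl)cc2)CC1` keeps the same two-carbon chain on the amide nitrogen but changes its end: methylsulfonyl in place of ((trifluoromethyl)sulfonyl)amino on a saturated chain carbon, two bonds along the chain from an amide-type nitrogen. Among the measured compounds shown here, no measured pair shows exactly this swap; the only step that bears on it is the one from compound 2 to compound 3, and it was modest. Compound 4 is expected to sit close to compound 3, perhaps a little back toward compound 2, with a 1.5-fold lower number from compound 3 to compound 4 (0.18 log units; within the scatter). The estimate for compound 4 in this assay is 0.6 nM, within 0.2 nM to 2 nM.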

Compound 4, half-maximal inhibitory concentration: 6.4 nM
For compound 4 the middle estimate is 11-fold (1.03 log units) below the measured one; the whole stated range lies below it.
By their numbers in this assay, from the lowest: compound 2; then compound 3; then compound 4; then compound 1.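

Moving the end of the tail matters at this position: in this assay there is a 7.1-fold higher number from compound 3 to compound 4 (0.85 log units; beyond the scatter) when methylsulfonyl replaces ((trifluoromethyl)sulfonyl)amino on the same chain. The tail is therefore not simply tolerated whatever its end, since a 21-fold higher number from compound 2 to compound 4 (1.33 log units; beyond the scatter) is a large step, while a 3.0-fold higher number from compound 2 to compound 3 (0.48 log units; beyond the scatter) is only a modest one. The swap removes a nitrogen, its hydrogen-bond donor and the trifluoromethyl group together, and nothing shown here accounts for the difference between the two tails.

These compounds cannot tell which of those removed parts counts, and a 2-((methylsulfonyl)amino)ethyl tail, which keeps the nitrogen but carries methyl in place of trifluoromethyl, would pull them apart. From the compounds shown here alone, how a longer chain or a terminal carboxylic acid or amine would read in this assay also remains open.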